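The compounds below may be only part of what the source reports. "The series", "measured", "known", "first", "only" and "open" are said of these compounds alone.

Measured so far:
- compound 1, `O=C1Nc2ccc(Br)cc2/C1=N/NC(=S)N/N=C/c1ccc(Br)cc1`, 4680 nM
- compound 2, `Cc1ccc2c(c1)/C(=N/NC(=S)N/N=C/c1ccccn1)C(=O)N2`, 3150 nM

Both numbers come from a functional assay on HeLa cells (Homo sapiens) for inhibition, read by MTT assay; on this read-out lower numbers stand for stronger inhibition and higher numbers for weaker inhibition. Compound 2 holds the lowest of the two numbers shown, and its nearest neighbour, compound 1, lies within the scatter of it; no step between the two measured compounds is given, so the pair only shows that their values sit close together. Compound 3, `Cc1ccc2c(c1)/C(=N/NC(=S)N/N=C/c1ccc(Br)cc1)C(=O)N2`, has not been measured in this assay. It differs from compound 2 by 4-bromophenyl in place of pyridin-2-yl on a carbon with a double bond to nitrogen. Compound 1 carries the same 4-bromophenyl group and sits within the scatter of compound 2, so no step beyond the scatter is expected from compound 2 to compound 3 in this assay: a 1.1-fold higher number from compound 2 to compound 3 (0.06 log units; within the scatter). Compound 3 is estimated at 3600 nM, between 1500 nM and 8500 nM.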

Compound 3, half-maximal inhibitory concentration: > 50000 nM
Compound 3 was reported as a limit (the forecaster's own chance of this, stated with the estimate: 5%); at least 13-fold (1.14 log units) between middle value and limit.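

In this assay, 4-bromophenyl in place of pyridin-2-yl on a carbon with a double bond to nitrogen gives an at least 15-fold higher number from compound 2 to compound 3 (1.20 log units; beyond the scatter), so this place is far from indifferent to the change. Methyl in place of bromo on an aromatic carbon, with 4-bromophenyl kept, gives an at least 10-fold higher number from compound 1 to compound 3 (1.02 log units; beyond the scatter), so the outcome of 4-bromophenyl depends on the group carried by the core. The value of compound 3 is a limit, not a number: the limit of > 50000 nM in this assay, at which 1 of the 3 values shown sits.

On these data alone, whether plain phenyl at this place, or chloro in place of the methyl, would follow compound 3 remains open.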